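The compounds below may be only part of what the source reports. "The series", "measured", "known", "first", "only" and "open" are said of these compounds alone.

Measured compounds:
compound 1 `CC1(C)CC(NC(=S)NCc2ccccc2)c2cc(Cl)ccc2O1`, 64000 nM;
compound 2 `CC1(C)CC(NC(=S)Nc2ccc([N+](=O)[O-])cc2)c2cc(Br)ccc2O1`, 9000 nM;
compound 3 `CC1(C)CC(NC(=S)Nc2ccc([N+](=O)[O-])cc2)c2cc(F)ccc2O1`, 3000 nM.

All three were tested in a functional assay on U-373MG ATCC cells (Homo sapiens) for inhibition, read by MTT assay, with a stated time of 72 h; on this read-out lower numbers stand for stronger inhibition and higher numbers for weaker inhibition. Compound 2 stands second highest of the three numbers: compound 3 lies a 3.0-fold lower number from compound 2 to compound 3 (0.48 log units; beyond the scatter) away, while compound 1 shows a higher number than compound 2. Compound 4 `COc1ccc(NC(=S)NC2CC(C)(C)Oc3ccc(Br)cc32)cc1` has not yet been measured. It differs from compound 2 in one place: methoxy in place of nitro on an aromatic carbon. No measured step touches this position; the single step shown, a 3.0-fold lower number from compound 2 to compound 3 (0.48 log units; beyond the scatter), swaps fluoro for bromo on the shared core and says nothing about the group on the six-membered aromatic ring of carbon only. The expectation is therefore a change within the scatter in this assay, estimated as a 1.3-fold higher number from compound 2 to compound 4 (0.12 log units; within the scatter). Compound 4 is expected to give 12000 nM, within 4000 nM to 40000 nM.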

Compound 4, half-maximal inhibitory concentration: 40000 nM
Beside the measured number, compound 4's estimate is 3.3-fold (0.52 log units) below it; the range from low to high includes it.
By their numbers in this assay, from the lowest: compound 3; then compound 2; then compounds 4 and 1 (each within the scatter of the next).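

In this assay, the group on the carbon-only aromatic ring turns out to matter: methoxy in place of nitro, para to a large group, gives a 4.4-fold higher number from compound 2 to compound 4 (0.65 log units; beyond the scatter) on the bromo core. Going by these compounds alone, the earlier step changed only the halogen, so this is the first sign that this position can move the number, with nitro giving the lower value of the pair. No measurement here accounts for the difference. The compounds shown leave open how an amine or a nitrile would behave at this position, and whether methoxy in place of nitro gives a similar step on the fluoro core of compound 3.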